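The compounds below may be only part of what the source reports. "The series", "measured", "known", "first", "only" and "open" are said of these compounds alone.

Measured compounds:
compound 1 `O=C(CCCCCCNC(=O)C(O)(O)C(F)(F)F)Nc1nc2ccc(Br)cc2o1` — 12100 nM
compound 2 `COc1ccccc1NC(=O)CCCCCCNC(=O)C(O)(O)C(F)(F)F` — 10100 nM
compound 3 `COc1ccc(OC)c(NC(=O)CCCCCCNC(=O)C(O)(O)C(F)(F)F)c1` — 3870 nM

In a functional assay on HCT-116 cells (Homo sapiens) for inhibition, read by colorimetric assay, with a stated time of 3 days (on this read-out lower numbers stand for stronger inhibition and higher numbers for weaker inhibition), compound 2 gives 10100 nM, the second highest of the three numbers; compound 1 lies within the scatter of it, while compound 3 sits apart, a 2.6-fold lower number from compound 2 to compound 3 (0.42 log units; beyond the scatter), the step being methoxy in place of hydrogen on an aromatic carbon.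

Compound 4 `O=C(CCCCCCNC(=O)C(O)(O)C(F)(F)F)Nc1ccccc1` is not yet measured. It differs from compound 2 by hydrogen in place of methoxy on an aromatic carbon, the remaining methoxy of compound 2 being removed. Among the compounds with values here, the only step that bears on this is the one from compound 2 to compound 3, where adding a methoxy lowered the number modestly; the present change runs the other way, taking a methoxy off. Within the data shown here, a small rise in the number, likely no larger than that step and possibly within the scatter, is therefore expected, giving a 1.5-fold higher number from compound 2 to compound 4 (0.17 log units; within the scatter). Compound 4 is estimated at 15000 nM in this assay, within 6000 nM to 40000 nM.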

Compound 4, half-maximal inhibitory concentration: 9140 nM
Beside the measured number, compound 4's estimate is 1.6-fold (0.22 log units) above it, and the stated range covers the measured number.
By their numbers in this assay, from the lowest: compound 3; then compounds 4, 2 and 1 (each within the scatter of the next).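

Taking the methoxy off the aromatic carbon ortho to a large group, the change from 2-methoxyphenyl to phenyl, gives a 1.1-fold lower number from compound 2 to compound 4 (0.04 log units; within the scatter) in this assay and so leaves the number where it was. Within the data shown here, the methoxy of compound 2 at this position is therefore not needed for the activity seen, whereas the added methoxy in a 2.6-fold lower number from compound 2 to compound 3 (0.42 log units; beyond the scatter) in this assay is the one change on this ring so far that moves the number beyond the scatter. No measurement at hand offers an explanation for this difference between the two methoxy changes.

Still open, as far as these compounds go, is whether the second methoxy of compound 3 would give the same step on the plain phenyl of compound 4, without the first methoxy. Also open, from the compounds shown here alone, is how an amine or a carboxylic acid on this ring, or a longer chain in the core, would affect the number.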